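The source may hold more compounds than are shown below. What is called first, only, known or untested is meant among the compounds shown, and "the series" means these compounds.

Measured compounds:
compound 1 `CC(C)c1onc(-c2c(Cl)cccc2Cl)c1COc1ccc(N(C)Cc2cccc(C(=O)O)c2)c(C(F)(F)F)n1` with 80 nM in a functional assay on HEK293 cells for agonist activity at Bile acid receptor (Homo sapiens); on this read-out higher numbers stand for an effect only at larger amounts of compound and lower numbers for an effect already at smaller amounts;
compound 2 `CN(Cc1cccc(C(=O)O)c1)c1ccc(OCc2c(-c3c(Cl)cccc3Cl)noc2C2CC2)nc1C(F)(F)F` with 9 nM in this assay;
compound 3 `CCN(Cc1ccc(C(=O)O)cc1)c1ccc(OCc2c(-c3c(Cl)cccc3Cl)noc2C2CC2)nc1C(F)(F)F` with 180 nM in this assay.

Among these three, compound 2 gives the lowest number. Among the measured compounds shown here, the one step that links it to a measured neighbour, an 8.9-fold lower number from compound 1 to compound 2 (0.95 log units; beyond the scatter), shows what the cyclopropyl in place of isopropyl brought. Compound 3 differs from compound 2 in more than one place, so its higher number cannot be assigned to any single change; it only shows that a compound carrying the carboxylic acid in the other position on the benzyl ring, together with ethyl in place of methyl, sits well above compound 2.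

Compound 4 `O=C(O)c1ccc(OCc2ccc(OCc3c(-c4c(Cl)cccc4Cl)noc3C3CC3)nc2C(F)(F)F)cc1` has not been measured. It differs from compound 2 in one place: (4-carboxyphenoxy)methyl in place of (3-carboxybenzyl)(methyl)amino on an aromatic carbon. For the measured compounds named here, no measured step covers this exchange of the amine-linked benzyl group for an ether-linked phenoxymethyl group, and the step from compound 1 to compound 2 concerns a different part of the molecule. The values of compound 2 and compound 3 suggest that altering this side of the core can cost activity, so compound 4 is expected to give a somewhat higher number, by a 5.6-fold higher number from compound 2 to compound 4 (0.74 log units; beyond the scatter), though with wide uncertainty. The estimate for compound 4 in this assay is 50 nM, within a range from 8 nM to 300 nM.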

Compound 4, half-maximal effective concentration: 95 nM
Compound 4: middle estimate off by 1.9-fold (0.28 log units), on the low side; measured number inside the range.
By their numbers in this assay, from the lowest: compound 2; then compounds 1, 4 and 3 (each within the scatter of the next, the first and the last beyond it).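

Among the compounds shown here, at the aromatic carbon ortho to the trifluoromethyl group, (4-carboxyphenoxy)methyl in place of (3-carboxybenzyl)(methyl)amino gives an 11-fold higher number from compound 2 to compound 4 (1.02 log units; beyond the scatter) in this assay, the first reading of a single change at this position, as the earlier step concerned the exchange of isopropyl for cyclopropyl elsewhere on the molecule. The two groups match in their carbon-only aromatic ring, their counts of hydrogen-bond donors and acceptors and their lack of net charge, so these shared features do not distinguish them, while the step still shows that the activity depends on what else differs between them. No available evidence accounts for the size of this step.

The exchange changes the atoms joining the aromatic ring to the core and the place of the carboxylic acid on that ring together, so the compounds shown do not assign the step to either one. Readings for (3-carboxyphenoxy)methyl or (4-carboxybenzyl)(methyl)amino at the same carbon would separate these two changes, and it remains open whether an ether-linked group can match the amine-linked group of compound 2.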